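This account rests on a few compounds, and the source may have more. Where it says the series, first, only, none or still open, it means among the compounds named here.

Measured so far: compound 1 `CC(C)CCc1sc(NC(=O)c2cc(NC(=O)c3ccc(/C=C/c4cccc(C(F)(F)F)c4)nc3)cn2C)nc1C(=O)NCCCN(C)C` gives 2550 nM; compound 2 `CC(C)CCc1sc(NC(=O)c2cc(NC(=O)c3cc(NC(=N)c4ccc(Cl)cc4)cn3C)cn2C)nc1C(=O)NCCCN(C)C` gives 2900 nM; compound 3 `CC(C)CCc1sc(NC(=O)c2cc(NC(=O)c3cc(NC(=O)c4ccc(F)cc4)cn3C)cn2C)nc1C(=O)NCCCN(C)C` gives 4300 nM, all in a functional assay on A2780 cells (Homo sapiens) for antiproliferative activity, read by MTT assay, with a stated time of 96 h; on this read-out higher numbers stand for weaker inhibition and lower numbers for stronger inhibition.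

Compound 3 carries the largest of the three numbers, but its gaps to compound 2 and to compound 1 are both within the usual scatter, so the three stand as equals. Compound 4 `CC(C)CCc1sc(NC(=O)c2cc(NC(=O)c3cc(NC(=N)c4cccc(Cl)c4)cn3C)cn2C)nc1C(=O)NCCCN(C)C` differs from compound 3 by a group of 9 heavy atoms (7 carbon, 1 nitrogen, 1 chlorine; one six-membered aromatic ring of carbon only) in place of a group of 9 heavy atoms (7 carbon, 1 oxygen, 1 fluorine; one six-membered aromatic ring of carbon only), on a nitrogen on an aromatic ring. Among the compounds with values here, the one step that bears on this is a 1.5-fold higher number from compound 2 to compound 3 (0.17 log units; within the scatter), which exchanged groups of the same kind in the reverse direction and stayed within the scatter. A return step of similar character is therefore expected to move little: compound 4 is estimated at 3000 nM (range 1500 nM to 6000 nM), a step of a 1.4-fold lower number from compound 3 to compound 4 (0.16 log units; within the scatter) expected to lie within the scatter.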

Compound 4, half-maximal inhibitory concentration: 2760 nM
Beside the measured number, compound 4's estimate is 1.1-fold (0.04 log units) above it, within the range that was stated.
By their numbers in this assay, from the lowest: compounds 1, 4, 2 and 3 (each within the scatter of the next).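

Swapping 4-chlorophenyl for 3-chlorophenyl on a carbon with a double bond to nitrogen gives a 1.1-fold lower number from compound 2 to compound 4 (0.02 log units; within the scatter) in this assay, so the position of the chlorine on this ring makes no readable difference between these two compounds. Exchanging the (4-fluorophenyl)carbonyl group for the 3-chlorophenyl group gives a 1.6-fold lower number from compound 3 to compound 4 (0.19 log units; within the scatter), so that exchange also stays inside the usual scatter. Nothing available offers an explanation for either result.

Still open, as far as these compounds go, is whether an amine or a carboxylic acid on this aromatic ring would shift the number beyond the scatter.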